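Swapping 4-hydroxyphenyl for 2-chlorophenyl on a sulfonamide nitrogen

The compounds below may be only part of what the source reports. "The series", "measured", "known", "first", "only" and "open" are said of these compounds alone.

Measured compounds:
- compound 1 `CCN(c1ccccc1)S(=O)(=O)C1CC2OC1C(c1ccc(NC(=O)CCCCCCC(=O)O)cc1)=C2c1ccc(O)cc1` gives > 100000 nM (a limit)
- compound 2 `CCN(c1ccc(OC)cc1)S(=O)(=O)C1CC2OC1C(c1ccc(NC(=O)CCCCCCC(=O)O)cc1)=C2c1ccc(O)cc1` gives > 100000 nM (a limit)
- compound 3 `CCN(c1ccc(O)cc1)S(=O)(=O)C1CC2OC1C(c1ccc(NC(=O)CCCCCCC(=O)O)cc1)=C2c1ccc(O)cc1` gives > 100000 nM (a limit)

In an ADME assay on Vero cells (Chlorocebus sabaeus) for antiproliferative activity, read by MTT assay, with a stated time of 72 h (a lower number here means a stronger inhibitor, a higher number a weaker inhibitor), compound 3 gives > 100000 nM as a limit of the assay and not a number. The whole set stands together (the limit of > 100000 nM in this assay, at which 3 of the 3 values shown sit) and none of it has a readable number. The next compound, compound 4 `CCN(c1ccccc1Cl)S(=O)(=O)C1CC2OC1C(c1ccc(NC(=O)CCCCCCC(=O)O)cc1)=C2c1ccc(O)cc1` carries 2-chlorophenyl in place of 4-hydroxyphenyl on a sulfonamide nitrogen and is otherwise unchanged. Three measured steps alter the ring on that nitrogen (a step that the two limits leave unreadable from compound 1 to compound 2) (a step that the two limits leave unreadable from compound 1 to compound 3) (a step that the two limits leave unreadable from compound 2 to compound 3) and none has a readable size. None of them brings in chlorine, so they guide this change only loosely. Still, all three compounds remain at the same limit with hydrogen, methoxy or hydroxy on that ring, so no move beyond the scatter is expected in this assay and no direction is favoured. The expected size is a number no higher from compound 3 to compound 4 (the limit leaves the size open) with a further limit the likeliest result. Compound 4 is expected near 100000 nM within an estimated range of 50000 nM to 200000 nM in this assay.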

Compound 4, half-maximal inhibitory concentration: > 100000 nM
Compound 4 ended at the assay's limit; the forecaster's own chance of this, stated with the estimate: 85%; the middle value lies on the limit itself.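

Compound 4, like compound 1, compound 2 and compound 3, stands at a limit and not a number in this assay, so none of its steps to them can be read: the limit of > 100000 nM in this assay, at which 4 of the 4 values shown sit.

The compounds shown leave open whether any of these rings on the sulfonamide nitrogen changes the result in this assay, and by how much.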